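This account rests on a few compounds, and the source may have more. Where it says the series, first, only, none or still open, it means among the compounds named here.

Compound 1 `COc1nc(-c2cc3ccccc3o2)cc(-c2ccc(F)cc2)c1C#N`, in a functional assay on aorta (strain Wistar) for inhibition, with Thoracic aorta (Rattus norvegicus) as the target (on this read-out lower numbers stand for stronger inhibition and higher numbers for weaker inhibition), gives 321000 nM.
Compound 2 `CCOc1nc(-c2cc3ccccc3o2)cc(-c2ccc(F)cc2)c1C#N` gives 396000 nM.
Compound 3 `COc1ccc(-c2cc(-c3cc4ccccc4o3)nc(OC)c2C#N)cc1` gives 262000 nM.

All three compounds share one core and differ only in small details at its edges. Compound 2 has the highest number of the three, yet the gaps are slight: the step of a 1.2-fold higher number from compound 1 to compound 2 (0.09 log units; within the scatter) separates it from compound 1, and its number and that of compound 3 lie within the usual scatter of each other, so no real ranking can be drawn among them.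

Compound 4 `CCOc1nc(-c2cc3ccccc3o2)cc(-c2cn(C)c3ccccc23)c1C#N` has not been measured. The change from compound 2 is 1-methyl-1H-indol-3-yl in place of 4-fluorophenyl on an aromatic carbon. Of the measured steps, a 1.2-fold lower number from compound 1 to compound 3 (0.09 log units; within the scatter) is the one that alters the 4-fluorophenyl group itself, and it was within the scatter. The other step, a 1.2-fold higher number from compound 1 to compound 2 (0.09 log units; within the scatter), concerns the ethoxy group and also stayed within the scatter. Neither replaces a whole ring with a larger two-ring group, so the data give no direct guide for this swap, and the expectation is a step of no clear size beyond the scatter, with a wide range around it. Compound 4 is therefore estimated at 350000 nM, with a range from 100000 nM to 1000000 nM, meaning an expected step of a 1.1-fold lower number from compound 2 to compound 4 (0.05 log units; within the scatter).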

Compound 4, half-maximal inhibitory concentration: 327000 nM
For compound 4 the middle estimate is 1.1-fold (0.03 log units) above the measured one; low and high end bracket the measured number.
By their numbers in this assay, from the lowest: compounds 3, 1, 4 and 2 (each within the scatter of the next).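

In this assay, the step from one ring to a larger two-ring group gives a 1.2-fold lower number from compound 2 to compound 4 (0.08 log units; within the scatter). This is a far bigger change to the group on the aromatic carbon opposite the ring nitrogen than the earlier swap of methoxy for fluoro on the phenyl ring, yet even replacing the whole 4-fluorophenyl group with 1-methyl-1H-indol-3-yl, which also brings a hydrogen-bond acceptor by the computed count, leaves the number within the scatter. No supporting measurement bears on this result, so the data offer no explanation for how closely the values agree.

On these data alone, every step among the four compounds lies within the scatter, so it remains open which part of the structure, if any, governs the number in this assay. Still untested among the compounds shown are a piperidine or a carboxylic acid in place of the aromatic group opposite the ring nitrogen and a butoxy chain in place of the ethoxy group, any of which might or might not produce a step beyond the scatter.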